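The source may hold more compounds than are shown below. What is called first, only, known or untested is meant among the compounds shown, and "the series" means these compounds.

The measured compounds:

Compound 1 `O=c1cc(N2CCN(CC3CCC(NS(=O)(=O)c4ccccc4)CC3)CC2)sc2c([N+](=O)[O-])cc(C(F)(F)F)cc12` gives > 64 ug/mL in an ADME assay on Vero cells (Chlorocebus sabaeus) for cytotoxicity, read by MTT assay, with a stated time of 48 h (a higher number here means a weaker inhibitor, a lower number a stronger inhibitor), which is a limit of the assay and not a number.
Compound 2 `O=c1cc(N2CCN(CC3CCC(OS(=O)(=O)c4ccccc4)CC3)CC2)sc2c([N+](=O)[O-])cc(C(F)(F)F)cc12` gives > 64 ug/mL in this assay, again a limit of the assay and not a number.

Compound 1 therefore stands only at a limit in this assay; no number fixes its position more closely. Among the measured compounds shown here, the single measured step, a step that the two limits leave unreadable from compound 1 to compound 2, cannot be read in size because both of its ends sit at the limit of > 64 ug/mL in this assay, at which 2 of the 2 values shown sit. It changes the same saturated ring carbon that matters here, but with a different group entering, and it yields no size and no direction.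

Compound 3 `O=C(OC1CCC(CN2CCN(c3cc(=O)c4cc(C(F)(F)F)cc([N+](=O)[O-])c4s3)CC2)CC1)c1cccs1` differs from compound 1 in one place: ((thiophen-2-yl)carbonyl)oxy in place of (phenylsulfonyl)amino on a saturated ring carbon. For the measured compounds named here, with the only measured step unreadable, no shift beyond the usual scatter can be expected in this assay in either direction. Compound 3 is therefore expected to stay at the limit, with a step that the limit leaves unreadable from compound 1 to compound 3 that is an estimate rather than a reading. The estimate for compound 3 in this assay is 80 ug/mL, expected to fall between 40 ug/mL and 160 ug/mL.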

Compound 3, half-maximal inhibitory concentration: > 64 ug/mL
Compound 3: only a limit was reported; the forecaster's own chance of this, stated with the estimate: 75%; the middle value is on the limit's open side.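

In this assay compound 3 gives > 64 ug/mL, which is a limit of the assay and not a number. Its steps from compound 1 and compound 2 therefore cannot be read, in size or in direction: the limit of > 64 ug/mL in this assay, at which 3 of the 3 values shown sit.

The compounds shown leave open whether these groups on the saturated ring carbon differ at all in this assay.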